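The source may report more compounds than this note shows. Statements on the series, on what has been measured and on what is new or still open speak of the compounds shown alone.

Compound 2 `CNC(=O)c1cc(Oc2ccc3nc(Nc4ccc(C(C)C)cc4)ncc3c2)ccn1` carries a 4-isopropylphenyl group on a nitrogen on an aromatic ring of the shared core. In an ADME assay on Caco-2 cells (Homo sapiens) for permeability, in the apical to basolateral direction (on this read-out higher numbers stand for higher permeability and lower numbers for lower permeability), compound 2 gives < 1 10^-6 cm/s, which is a limit of the assay and not a measured number. Its neighbour, compound 1 `CCc1ccccc1Nc1ncc2cc(Oc3ccnc(C(=O)NC)c3)ccc2n1`, differs only in bearing 2-ethylphenyl at that nitrogen. In this assay compound 1 also gives < 1 10^-6 cm/s, again a limit. The step that the two limits leave unreadable from compound 1 to compound 2 therefore cannot be read, and it tells nothing about how compound 2 would move with a further change; both values rest at the limit of < 1 10^-6 cm/s in this assay, at which 2 of the 2 values shown sit. Compound 3 `CNC(=O)c1cc(Oc2ccc3nc(Nc4ccc(-c5cccnc5)cc4)ncc3c2)ccn1` is not yet measured. It differs from compound 2 by pyridin-3-yl in place of isopropyl on an aromatic carbon. For the measured compounds named here, no measured step bears on this change; the one step at hand is unreadable, so no direction beyond the scatter can be argued from the data. Compound 3 is expected to stay at the limit, with an estimated value of 0.7 10^-6 cm/s in the range 0.2 10^-6 cm/s to 3 10^-6 cm/s. The step this estimate means, a step that the limit leaves unreadable from compound 2 to compound 3, is expected to lie within the scatter.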

Compound 3, apparent permeability: < 1 10^-6 cm/s
Compound 3: only a limit was reported (the forecaster's own chance of this, stated with the estimate: 70%); the middle value lies beyond the limit too.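

The step from compound 2 to compound 3 cannot be read, since in this assay both compounds give only a limit of the assay and no measured number: the limit of < 1 10^-6 cm/s in this assay, at which 3 of the 3 values shown sit.

The compounds shown leave open how compound 1, compound 2 and compound 3 rank in this assay, and whether either change between them moves the read-out at all.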